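The compounds below may be only part of what the source reports. "The series", "measured", "known", "first", "only" and "open" are said of these compounds alone.

Measured so far, in a functional assay on HepG2 cells (Homo sapiens) for inhibition, read by MTT assay, with a stated time of 72 h; a lower number here means a stronger inhibitor, a higher number a weaker inhibitor:

- Compound 1 `C#CCSc1nc(NCCC(C)C)c2ccncc2n1` gives > 80000 nM; this is a limit of the assay, not a number.
- Compound 2 `C#CCSc1nc(Nc2ccccc2)c2ccncc2n1` gives 29400 nM.
- Compound 3 `C#CCSc1nc(Nc2ccc(C)cc2)c2ccncc2n1` gives 6170 nM.

All three share the same core and differ only in the group on a nitrogen on an aromatic ring. Compound 3 holds the lowest of the two numbers actually measured; its nearest neighbour is compound 2, and the step of a 4.8-fold lower number from compound 2 to compound 3 (0.68 log units; beyond the scatter) sets the gap between them. Against compound 1 the step of an at least 12-fold lower number from compound 1 to compound 3 (1.11 log units; beyond the scatter) is larger still, though compound 1 sits at the limit of > 80000 nM in this assay, at which 1 of the 3 values shown sits, and so only a lower bound of that step is known. The step of an at least 2.7-fold lower number from compound 1 to compound 2 (0.43 log units; beyond the scatter) shows that the ring alone already moves the number.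

Compound 4 `C#CCSc1nc(Nc2ccccc2Cl)c2ccncc2n1` is not yet measured. It differs from compound 3 in one place: 2-chlorophenyl in place of 4-methylphenyl on a nitrogen on an aromatic ring. Among the compounds with values here, two steps bear on this. The methyl that enters in a 4.8-fold lower number from compound 2 to compound 3 (0.68 log units; beyond the scatter) is lost again here, which on its own points back toward the number of compound 2. What a chlorine on the ring does is not shown by any measured pair, so no step speaks to it. The change is therefore expected to give a modestly higher number, a 2.4-fold higher number from compound 3 to compound 4 (0.39 log units; beyond the scatter), with a wide range. For compound 4 the estimate in this assay is 15000 nM, between 4000 nM and 60000 nM.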

Compound 4, half-maximal inhibitory concentration: 17200 nM
Beside the measured number, compound 4's estimate is 1.1-fold (0.06 log units) below it; the measured number falls inside the stated range.
By their numbers in this assay, from the lowest: compound 3; then compounds 4 and 2 (each within the scatter of the next). At a limit, above all of these: compound 1.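

In this assay, the chlorine does not repeat what the methyl did: a 1.7-fold lower number from compound 2 to compound 4 (0.23 log units; within the scatter), whereas the methyl gave a 4.8-fold lower number from compound 2 to compound 3 (0.68 log units; beyond the scatter). So a group added to the phenyl ring on this nitrogen does not always separate the compound from the unsubstituted phenyl, and the two substituted rings also stand apart from each other: a 2.8-fold higher number from compound 3 to compound 4 (0.45 log units; beyond the scatter). The step of an at least 4.6-fold lower number from compound 1 to compound 4 (0.66 log units; beyond the scatter) shows that 2-chlorophenyl, like the two earlier aromatic rings, gives a lower number than isopentyl, but its size is only a bound, since the value of compound 1 is a limit of the assay and not a number: the limit of > 80000 nM in this assay, at which 1 of the 4 values shown sits.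

Compound 3 and compound 4 differ in both the kind of group on the ring and where it sits, so these compounds cannot say which of the two accounts for the gap between them. From the compounds shown here alone, how a methoxy group, a fluorine or an amine on the phenyl ring would compare with methyl and chlorine also remains open.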